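A Methoxy in Place of a Methyl

The compounds below may be only part of what the source reports. "The series", "measured", "known", "first", "only" and "open" are said of these compounds alone.

Measured in a functional assay on HT-29 cells (Homo sapiens) for cytotoxicity, read by MTT assay, with a stated time of 6 days (a higher number here means a weaker inhibitor, a lower number a stronger inhibitor), so far:
- compound 1 `Cc1ccc2c(c1)OCC(=O)N2Cc1cn(Cc2ccccc2)nn1` gives 54900 nM as a number
- compound 2 `Cc1ccc2c(c1)N(Cc1cn(Cc3ccccc3)nn1)C(=O)CO2` gives > 100000 nM as a limit

For compound 2 the reading of > 100000 nM is a limit of the assay and not a number. Compound 3 `COc1ccc2c(c1)N(Cc1cn(Cc3ccccc3)nn1)C(=O)CO2` differs from compound 2 by methoxy in place of methyl on an aromatic carbon in the shared core. Among the measured compounds shown here, no measured pair shows this change, so no step beyond the usual scatter is expected in this assay here. The estimated step is an at least 1.1-fold lower number from compound 2 to compound 3 (0.04 log units; that floor lies within the scatter) and no larger. For compound 3 the estimate is 90000 nM within an expected range from 35000 nM to 200000 nM and another limit reading remains quite possible.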

Compound 3, half-maximal inhibitory concentration: > 100000 nM
Compound 3: no number, only a limit (the forecaster's own chance of this, stated with the estimate: 60%); middle value at least 1.1-fold (0.04 log units) away from the limit.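

Compound 2 and compound 3 both read as limits in this assay, so no step can be read between them: the limit of > 100000 nM in this assay, at which 2 of the 3 values shown sit.

From the compounds shown here alone, whether methoxy in place of methyl on an aromatic carbon changes the reading at all stays open.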